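Methylsulfanyl for Chloro on Two Related Cores

The source may hold more compounds than are shown below. What is called first, only, known or untested is meant among the compounds shown, and "the series" means these compounds.

Compound 1, `COc1cc(SC)nc(NC(=S)NC(=O)c2c(-c3ccc(Cl)cc3Cl)noc2C)n1`: 60.3%
Compound 2, `COc1cc(Cl)nc(NC(=S)NC(=O)c2c(-c3ccc(Cl)cc3Cl)noc2C)n1`: 53.2%
Compound 3, `COc1cc(Cl)nc2n/c(=N/C(=O)c3c(-c4ccc(Cl)cc4Cl)noc3C)sn12`: 65.9%

In a functional assay on the whole organism for inhibition, with Chenopodium ficifolium as the target, with a stated time of 72 h, tested at 100 mg/L (a higher number here means more inhibition of growth at the concentration tested, a lower number less inhibition of growth), compound 3 gives the highest of the three numbers, though its gap to compound 1 lies within the scatter; only its gap to compound 2 lies beyond it. Compound 1 and compound 2 share a core and differ by methylsulfanyl in place of chloro on an aromatic carbon; this change made a number 7.1 percentage points higher from compound 2 to compound 1 (within the scatter). The core of compound 3 differs from that of compound 2, but the difference between the two cores is not broken down here. Compound 4, `COc1cc(SC)nc2n/c(=N/C(=O)c3c(-c4ccc(Cl)cc4Cl)noc3C)sn12`, is unmeasured and arises from compound 3 by methylsulfanyl in place of chloro on an aromatic carbon. This is the same kind of change as from compound 2 to compound 1, but its place is part of a fused or bridged system of two rings, meta to a fused ring and para to a fused ring, rather than meta to a large group. Because the step of a number 7.1 percentage points higher from compound 2 to compound 1 (within the scatter) lay within the scatter, compound 4 is expected to show a similarly small step, a number 4.1 percentage points higher from compound 3 to compound 4 (within the scatter), in this assay. Compound 4 is thus estimated at 70%, between 58% and 82%.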

Compound 4, percent growth inhibition at one concentration: 68.3%
For compound 4 the middle estimate is 1.7 percentage points above the measured one; measured number inside the range.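

In this assay, methylsulfanyl in place of chloro on the core of compound 3 gave a number 2.4 percentage points higher from compound 3 to compound 4 (within the scatter). Set beside the earlier step on the other core, the two do not differ by more than repeated measurement allows: the same change on two cores in this assay, a number 7.1 percentage points higher (within the scatter) from compound 2 to compound 1 and a number 2.4 percentage points higher (within the scatter) from compound 3 to compound 4, 4.7 percentage points apart, within the scatter of two such steps This shows that the change reads alike on these two cores, but it does not show that the change raises growth inhibition on either core, since each step lies within the scatter, and two cores say nothing about any others.

The compounds shown leave open how an amine or a longer alkylsulfanyl chain would read in place of the methylsulfanyl group. From the compounds shown here alone, whether the two steps would also agree at other concentrations or on other plant species remains open as well.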